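The compounds below may be only part of what the source reports. "The series", "measured", "known", "first", "only" and "open" are said of these compounds alone.

Measured so far in an ADME assay on microsomes from liver (Homo sapiens) for metabolic stability, with a stated time of 60 min, tested at 1 mg/mL; on this read-out lower numbers stand for slow clearance and higher numbers for fast clearance:
- compound 1 `COc1nc2ccc(Br)cc2cc1[C@@H](c1cncc(C)c1)[C@@](O)(CCN(C)C)c1cccc(F)c1`: 56 mL.min-1.g-1
- compound 2 `COc1nc2ccc(Br)cc2cc1[C@@H](c1cccnc1N(C)C)[C@@](O)(CCN(C)C)c1cccc(F)c1`: 45 mL.min-1.g-1

Only these two numbers exist so far, and compound 2 sits within the usual scatter of compound 1, so neither stands apart from the other.

The next compound, compound 3 `COc1cc([C@H](c2cc3cc(Br)ccc3nc2OC)[C@@](O)(CCN(C)C)c2cccc(F)c2)cnc1OC`, keeps the shared core and changes one group: 5,6-dimethoxypyridin-3-yl in place of 2-(dimethylamino)pyridin-3-yl on a saturated chain carbon bound to an aromatic carbon and a saturated chain carbon. This puts 5,6-dimethoxypyridin-3-yl in place of 2-(dimethylamino)pyridin-3-yl on a saturated chain carbon bound to an aromatic carbon and a saturated chain carbon.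

Going by the values given here, one measured step bears on this, a swap at the same place, with 2-(dimethylamino)pyridin-3-yl in place of 5-methylpyridin-3-yl: a 1.2-fold lower number from compound 1 to compound 2 (0.09 log units; within the scatter). Among the compounds with values here, no measured compound carries the 5,6-dimethoxypyridin-3-yl group, so this evidence is thin. Going by that small step and by compound 2 at 45 mL.min-1.g-1, no shift beyond the scatter is expected in this assay, in either direction.

The expected change is a 1.1-fold higher number from compound 2 to compound 3 (0.05 log units; within the scatter). For compound 3 the estimated value is 50 mL.min-1.g-1, with an expected range of 26 mL.min-1.g-1 to 95 mL.min-1.g-1.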

Compound 3, intrinsic clearance in microsomes: 36 mL.min-1.g-1
Beside the measured number, compound 3's estimate is 1.4-fold (0.14 log units) above it; low and high end bracket the measured number.
By their numbers in this assay, from the lowest: compounds 3, 2 and 1 (each within the scatter of the next).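

In this assay, the swap to 5,6-dimethoxypyridin-3-yl on this saturated chain carbon gives a 1.3-fold lower number from compound 2 to compound 3 (0.10 log units; within the scatter), and the same group set against 5-methylpyridin-3-yl gives a 1.6-fold lower number from compound 1 to compound 3 (0.19 log units; within the scatter). Oxygen atoms now enter at this place for the first time, yet both steps stay within the scatter, so across these three compounds the group at this carbon has not produced a difference that can be told apart from the noise of repeat measurements. Nothing in the data shown gives a reason for these numbers.

On these data alone, all three groups at this place are six-membered aromatic rings with 1 hetero atom, so it stays open whether a group of another kind, such as a saturated piperidine ring or a carboxylic acid, would move the number beyond the scatter. Also open, as far as these compounds go, is how the number would respond to a longer chain carrying the dimethylamino group, since that part of the molecule is the same in all three compounds.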